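This account rests on a few compounds, and the source may have more. Where it says the series, first, only, none or still open, it means among the compounds named here.

Measured compounds:
- compound 1, `CC(=O)O[C@@H]1OC(=O)[C@](C)(C(C)=O)[C@@H]1C`: 4000 nM
- compound 2, `CC(=O)O[C@@H]1OC(=O)[C@@](C)(C(C)=O)[C@@H]1C`: 14000 nM
- compound 3, `CC(=O)O[C@@H]1OC(=O)[C@@](O)(C(C)=O)[C@@H]1C`: reported only as a limit, > 50000 nM

In a functional assay on B16 cells (Mus musculus) for cytotoxicity, read by MTT assay (on this read-out higher numbers stand for weaker inhibition and lower numbers for stronger inhibition), compound 2 gives the highest of the two numbers shown, with compound 1 the nearest. The value given for compound 3 is a limit of the assay and not a number (the limit of > 50000 nM in this assay, at which 1 of the 3 values shown sits). Two measured steps exist. The step of a 3.5-fold higher number from compound 1 to compound 2 (0.54 log units; beyond the scatter) rests on a difference in configuration alone (the fact that compounds 1 and 2 differ only in the configuration as drawn). The step of an at least 3.5-fold higher number from compound 2 to compound 3 (0.55 log units; beyond the scatter) comes from hydroxy in place of methyl on a saturated ring carbon.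

Compound 4, `CC(=O)[C@]1(C)C(=O)O[C@@H](OC(=O)c2ccccc2)[C@H]1C`, is not yet measured. It differs from compound 2 by phenyl in place of methyl on a carbonyl carbon. Neither measured step touches this part of the shared core, so none of them bears directly on the change; both were of modest size, and a step of similar size, in either direction, seems the most that the data support. For compound 4 in this assay an estimate of 8000 nM is expected, with a range from 2500 nM to 30000 nM. This corresponds to an expected step of a 1.8-fold lower number from compound 2 to compound 4 (0.24 log units; within the scatter).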

Compound 4, half-maximal inhibitory concentration: 5000 nM
Compound 4: the middle estimate sits 1.6-fold (0.20 log units) above what was measured, within the range that was stated.
By their numbers in this assay, from the lowest: compounds 1 and 4 (each within the scatter of the next); then compound 2. At a limit, above all of these: compound 3.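

In this assay, within the data shown here, phenyl in place of methyl on a carbonyl carbon gives a 2.8-fold lower number from compound 2 to compound 4 (0.45 log units; beyond the scatter) and is the first measured change at this position, as the earlier steps touched only a saturated ring carbon and a configuration. Both of those steps raised the number, whereas this one lowers it, so here a change leads to stronger inhibition. The position therefore takes a group of 6 heavy atoms with an aromatic ring in place of a single methyl, and the cytotoxic effect is not lost.

Going by these compounds, how ethyl, a longer chain, or a phenyl ring carrying an amine or a carboxylic acid would behave on this carbonyl carbon remains open. Nothing among the measured facts explains why phenyl lowers the number.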